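Swapping methyl for phenyl on the thioester carbonyl

The source may report more compounds than this note shows. Statements on the series, on what has been measured and on what is new or still open speak of the compounds shown alone.

Measured in a functional assay on RAW264.7 cells (Mus musculus) for inhibition, read by Griess assay, with a stated time of 24 h; a lower number here means a stronger inhibitor, a higher number a weaker inhibitor:
- compound 1 `CC(=O)S[C@@]12CC[C@H](O)[C@@H]1C(=O)NC2=O`: 148000 nM
- compound 2 `CC(=O)S[C@]12CC[C@H](O)[C@H]1C(=O)NC2=O`: 833000 nM

Of these two, compound 1 has the lower number and so is the stronger inhibitor. Among the compounds with values here, the only measured step is a 5.6-fold higher number from compound 1 to compound 2 (0.75 log units; beyond the scatter), and it reflects (the fact that compounds 1 and 2 differ only in the configuration as drawn). Compound 3 `O=C(S[C@@]12CC[C@H](O)[C@@H]1C(=O)NC2=O)c1ccccc1` keeps the core of compound 1 but changes one group: phenyl in place of methyl on a carbonyl carbon. Within the data shown here, compound 1 and compound 2 both carry the methyl, so no measured step tests this swap. The step to compound 2 offers only a rough sense of size, and no direction can be drawn from it. The expected change is therefore none beyond the scatter, an estimated 1.1-fold lower number from compound 1 to compound 3 (0.02 log units; within the scatter) in this assay. For compound 3 the estimated value is 140000 nM, with an expected range from 40000 nM to 450000 nM.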

Compound 3, half-maximal inhibitory concentration: 72400 nM
For compound 3 the middle estimate is 1.9-fold (0.29 log units) above the measured one; the measured number falls inside the stated range.
By their numbers in this assay, from the lowest: compound 3; then compound 1; then compound 2.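

In this assay phenyl in place of methyl gives a 2.0-fold lower number from compound 1 to compound 3 (0.31 log units; beyond the scatter) and so shows that the group on this carbonyl carbon can change the number, with a ring accepted there without any loss of strength. Nothing at hand explains this gain.

From the compounds shown here alone, whether it belongs to the aromatic ring or would come with any larger group stays open: ethyl or cyclohexyl in the same place could help separate these. Also open, going by these compounds, is whether phenyl gives a similar step on the configuration of compound 2.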